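A few compounds are considered here, and "the series" means these few. Any claim that something is new, unique, unknown or untested is made for them only; others in the source may bear on it.

Measured so far:

Compound 1 `COc1ccc(-c2nc(C)c(C(=O)CSc3nc(-c4ccc(Cl)cc4)c(C#N)c(=O)[nH]3)s2)cc1`: 48%
Compound 2 `COc1ccc(-c2nc(C)c(C(=O)CSc3nc(-c4cccc(OC)c4)c(C#N)c(=O)[nH]3)s2)cc1`: 43.2%
Compound 3 `Cc1nc(-c2ccc(Cl)cc2)sc1C(=O)CSc1nc(-c2ccc(Cl)cc2)c(C#N)c(=O)[nH]1`: 60%

These three were tested in a functional assay on U-87MG ATCC cells for antiproliferative activity against U-87 MG (Homo sapiens), read by MTT assay, with a stated time of 48 h, tested at 50 uM; a lower number here means a stronger effect, a higher number a weaker effect of the compound at the concentration tested. Compound 4 `COc1cccc(-c2nc(SCC(=O)c3sc(-c4ccc(Cl)cc4)nc3C)[nH]c(=O)c2C#N)c1` has not yet been measured in this assay. It differs from compound 3 by one change, (3-methoxyphenyl in place of 4-chlorophenyl on an aromatic carbon). The same kind of change separates compound 1 from compound 2, (3-methoxyphenyl in place of 4-chlorophenyl on an aromatic carbon), and the place of the change is described in the same words for both pairs. That earlier change moved the read-out by a number 4.8 percentage points lower from compound 1 to compound 2 (within the scatter). The two cores differ in one other way, (chloro in place of methoxy on an aromatic carbon), which in the measured compounds gave a number 12 percentage points higher from compound 1 to compound 3 (beyond the scatter), so compound 3 has the weakest effect of the three at this concentration.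

Because the change from compound 1 to compound 2 gave a number 4.8 percentage points lower from compound 1 to compound 2 (within the scatter), the step from compound 3 to compound 4 is expected to be small, about a number 5 percentage points lower from compound 3 to compound 4 (within the scatter). On that basis compound 4 is estimated to give 55% in this assay, expected to fall between 44% and 66%.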

Compound 4, a percentage reported as activity, at one concentration (the size of the read-out at that concentration, not a potency): 47.6%
For compound 4 the middle estimate is 7.4 percentage points above the measured one; measured number inside the range.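

Putting 3-methoxyphenyl in place of 4-chlorophenyl gave a number 12.4 percentage points lower from compound 3 to compound 4 (beyond the scatter) in this assay, and this step agrees with the earlier one on the other core as far as the scatter allows: the same change on two cores in this assay, a number 4.8 percentage points lower (within the scatter) from compound 1 to compound 2 and a number 12.4 percentage points lower (beyond the scatter) from compound 3 to compound 4, 7.6 percentage points apart, within the scatter of two such steps. The second change, chloro in place of methoxy, gave a number 4.4 percentage points higher from compound 2 to compound 4 (within the scatter), and it too agrees with its earlier step: the same change on two cores in this assay, a number 12 percentage points higher (beyond the scatter) from compound 1 to compound 3 and a number 4.4 percentage points higher (within the scatter) from compound 2 to compound 4, 7.6 percentage points apart, within the scatter of two such steps. Going by these compounds alone, these four compounds, tested at one concentration, show only that each change can be carried between these two cores without a difference beyond the scatter; they do not fix the size of either change, and they do not show that it would hold on a third core.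

As far as these compounds go, it remains open what a quite different group at this place on the shared core, such as an amine or a carboxylic acid, would do to the read-out. A read-out at one concentration also leaves open how the effects of these compounds would compare at any other concentration.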